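Swapping the sulfonyl group: compound 3 to compound 4

The compounds below may be only part of what the source reports. "The series", "measured", "known", "first", "only" and "open" are said of these compounds alone.

In an ADME assay on microsomes from liver (Homo sapiens) for pharmacokinetics, read by LC-MS, with a stated time of 60 min, tested at 1 uM (a higher number here means faster removal of the compound, a lower number slower removal), compound 3 (`O=C(NCc1ccc(S(=O)(=O)C2CCN(C3COC3)CC2)cc1)N1Cc2ccncc2C1`) gives 10 mL/min/kg and lies within the scatter of compound 1 (`CCCn1cc(S(=O)(=O)c2ccc(CNC(=O)N3Cc4ccncc4C3)cc2)cn1`) with 11 mL/min/kg and of compound 2 (`O=C(NCc1ccc(S(=O)(=O)C2CCCCC2)cc1)N1Cc2ccncc2C1`) with 16 mL/min/kg in this series. Compound 4 (`O=C(NCc1ccc(S(=O)(=O)N2CCC[C@H](O)C2)cc1)N1Cc2ccncc2C1`) has 3-hydroxypiperidin-1-yl in place of 1-(oxetan-3-yl)piperidin-4-yl on the sulfonyl sulfur (3-hydroxypiperidin-1-yl in place of 1-(oxetan-3-yl)piperidin-4-yl on a sulfonyl sulfur). The swaps measured on that sulfur give a 1.5-fold higher number from compound 1 to compound 2 (0.16 log units; within the scatter) and a 1.1-fold lower number from compound 1 to compound 3 (0.04 log units; within the scatter) and a 1.6-fold lower number from compound 2 to compound 3 (0.20 log units; within the scatter) and all stay within the scatter. None of these compounds carries 3-hydroxypiperidin-1-yl, so the evidence is indirect. The expected step in this assay is a 1.1-fold higher number from compound 3 to compound 4 (0.04 log units; within the scatter) and stays within the scatter. For compound 4 the estimated value is 11 mL/min/kg with an expected range from 6 mL/min/kg to 20 mL/min/kg on this read-out.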

Compound 4, clearance: 8 mL/min/kg
Beside the measured number, compound 4's estimate is 1.4-fold (0.14 log units) above it; the range from low to high includes it.
By their numbers in this assay, from the lowest: compounds 4, 3, 1 and 2 (each within the scatter of the next).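

On the sulfonyl sulfur, a ring bearing a hydroxyl and a hydrogen-bond donor, 3-hydroxypiperidin-1-yl, now sits alongside the earlier groups in this assay: a 1.3-fold lower number from compound 3 to compound 4 (0.10 log units; within the scatter) and a 1.4-fold lower number from compound 1 to compound 4 (0.14 log units; within the scatter) and a 2.0-fold lower number from compound 2 to compound 4 (0.30 log units; within the scatter) all stay within the scatter. Four differently built groups at this position therefore give numbers that do not separate from one another. No supporting data bear on why this swap leaves the read-out within the scatter.

Going by these compounds, whether plain piperidin-1-yl without the hydroxyl or the opposite enantiomer of 3-hydroxypiperidin-1-yl would read the same remains open. A carboxylic acid on the sulfonyl substituent also remains untested in the compounds shown here.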